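The source may report more compounds than this note shows. Statements on the series, on what has been measured and on what is new or still open speak of the compounds shown alone.

Measured in a functional assay on HCT-116 cells (Homo sapiens) for inhibition, read by MTT assay, with a stated time of 72 h, in the presence of a further agent that is not named here; on this read-out higher numbers stand for an effect only at larger amounts of compound and lower numbers for an effect already at smaller amounts:
- compound 1 `CN(C)c1nc(NNC(=O)Nc2cc(Cl)nc(Cl)c2)nc2c1ccn2C`: 41500 nM
- compound 2 `CNc1cc(C)nc(NNC(=O)Nc2cc(Cl)nc(Cl)c2)n1`: 23400 nM
- compound 3 `O=C(Nc1cc(Cl)nc(Cl)c1)Nc1cc(Cl)nc(Cl)c1`: 180 nM

Compound 3 has the lowest number of the three, and its gaps to compound 2 and compound 1 both lie beyond the scatter. Compound 4 `CC(C)Oc1cc(NC(=O)Nc2cc(Cl)nc(Cl)c2)cc(Cl)n1` carries isopropoxy in place of chloro on an aromatic carbon, next to the ring nitrogen of a six-membered aromatic ring with 1 nitrogen: isopropoxy in place of chloro on an aromatic carbon. Within the data shown here, no measured pair isolates a change at this place, so any expectation is weakly anchored. Among the measured compounds shown here, the only close reference is compound 3 at 180 nM. A moderate rise in the number is expected in this assay, possibly not much beyond the scatter, though a larger loss cannot be excluded. The expected size of the change is a 2.5-fold higher number from compound 3 to compound 4 (0.40 log units; beyond the scatter). Compound 4 is estimated at 450 nM, with an expected range of 100 nM to 3000 nM.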

Compound 4, half-maximal effective concentration: 5230 nM
For compound 4 the middle estimate is 12-fold (1.07 log units) below the measured one; the whole stated range lies below it.
By their numbers in this assay, from the lowest: compound 3; then compound 4; then compounds 2 and 1 (each within the scatter of the next).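

In this assay the exchange of chloro for isopropoxy on an aromatic carbon, next to the ring nitrogen, gives a 29-fold higher number from compound 3 to compound 4 (1.46 log units; beyond the scatter) and is thus a large step. Among these compounds, this is the first reading at this position, and it shows that the number here depends strongly on the group at this one carbon, even with the other chloro on this ring and the second ring unchanged. Nothing measured on these compounds accounts for the size of the step.

The compounds shown do not separate the loss of chloro from the entry of isopropoxy, and only one replacing group has been read at this carbon. Methoxy or an amine on the same carbon would show whether the rise in the number holds for other groups or belongs to isopropoxy alone.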